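A few compounds are considered here, and "the series" means these few. Any claim that something is new, unique, unknown or untested is made for them only; others in the source may bear on it.

Compound 1 `CC(C(=O)NCc1ccc(C(F)(F)F)nc1N(C)C)c1ccc(NS(C)(=O)=O)c(F)c1`: 2390 nM
Compound 2 `CC(C(=O)NCc1ccc(C(F)(F)F)nc1N1CCC2(CC1)CC(C(C)(C)C)=NO2)c1ccc(NS(C)(=O)=O)c(F)c1`: 281 nM

Among the compounds with values here, in a functional assay on CHO-K1 cells for antagonist activity at transient receptor potential cation channel subfamily V member 1 (Homo sapiens), read by FLIPR (a lower number here means a stronger inhibitor, a higher number a weaker inhibitor), compound 1 gives 2390 nM, the higher of the two numbers measured so far. Compound 2 gives 281 nM in this assay, a lower value that lies beyond the usual scatter of repeated measurements, so compound 2 is the stronger inhibitor of the pair.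

Compound 3 `CC(C(=O)NCc1ccc(C(F)(F)F)nc1N1CCCCCC1)c1ccc(NS(C)(=O)=O)c(F)c1` has not yet been measured. It differs from compound 1 in one place: azepan-1-yl in place of dimethylamino on an aromatic carbon. Within the data shown here, with only two measured compounds to lean on, the step is expected to be moderate and toward a lower number, a 3.4-fold lower number from compound 1 to compound 3 (0.53 log units; beyond the scatter). For compound 3 in this assay a value of about 700 nM is estimated, within a range of 250 nM to 2000 nM.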

Compound 3, half-maximal inhibitory concentration: 25.1 nM
Estimate against measurement, compound 3: 28-fold (1.45 log units) above; the whole stated range lies above it.
By their numbers in this assay, from the lowest: compound 3; then compound 2; then compound 1.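

Replacing dimethylamino with azepan-1-yl gives a 95-fold lower number from compound 1 to compound 3 (1.98 log units; beyond the scatter) in this assay and shows that the group on this aromatic carbon, next to the ring nitrogen, can change inhibitor strength greatly. A large step of this kind was not visible from the earlier values alone. No available evidence explains the gain.

As far as these compounds go, it remains open whether the ring itself matters or only the number of carbons. Pyrrolidin-1-yl, piperidin-1-yl and an open-chain dipropylamino group would help separate those two possibilities.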